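A Ring Swap at the Low End of Solubility

The compounds below may be only part of what the source reports. "The series", "measured", "known", "first", "only" and "open" are said of these compounds alone.

Among the compounds with values here, compound 1 `O=C(Nc1ccc(C(F)(F)F)cc1)NC1CCN(C(=O)C2CCCOC2)CC1` stands lowest of the three compounds measured so far in a physicochemical assay for solubility, read by mass spectrometry, in phosphate buffer, with a stated time of 24 h, at pH 7.4; on this read-out lower numbers stand for lower solubility and higher numbers for higher solubility. There compound 1 gives 1.1 ug/mL as its reading, while compound 2 `O=C(Nc1ccc(OC(F)(F)F)c(F)c1)NC1CCN(C(=O)C2CC2)CC1` gives 19 ug/mL and compound 3 `O=C(Nc1ccc(OC(F)(F)F)cc1)NC1CCN(C(=O)C2CCOCC2)CC1` gives 91 ug/mL in the same test. Both gaps are well beyond the usual scatter, but these two compounds differ from compound 1 in more than one place, so neither gap isolates a single change.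

Compound 4 `O=C(Nc1ccc(C(F)(F)F)cc1)NC1CCN(C(=O)[C@@H]2CCOC2)CC1` keeps the rest of compound 1 and carries oxolan-3-yl in place of oxan-3-yl on a carbonyl carbon. Within the data shown here, no measured pair shows this swap directly, so any forecast in this assay is uncertain. Among the measured compounds shown here, the change touches only one ring, and a small upward move is expected, with the estimated size given as a 3.2-fold higher number from compound 1 to compound 4 (0.50 log units; beyond the scatter) on this scale. For compound 4 the expected value is 3.5 ug/mL with an estimated range from 1 ug/mL to 15 ug/mL in this test.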

Compound 4, solubility: 1.4 ug/mL
Compound 4: the middle estimate sits 2.5-fold (0.40 log units) above what was measured; low and high end bracket the measured number.
By their numbers in this assay, from the lowest: compounds 1 and 4 (each within the scatter of the next); then compound 2; then compound 3.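

In this assay, within the data shown here, the first comparison in this set that differs in only one place reads a 1.3-fold higher number from compound 1 to compound 4 (0.10 log units; within the scatter) for the swap of oxan-3-yl to oxolan-3-yl on a carbonyl carbon. Going from a six-membered to a five-membered non-aromatic ring, with one oxygen kept in the ring, therefore does not separate the two compounds in this test. No supporting measurement is available to explain why this pair reads alike.

Among these compounds, this single pair covers only two closely related oxygen-bearing rings, so it says nothing about how a different kind of group, such as a ring with a basic amine or a carboxylic acid, would read at this place. Also open, as far as these compounds go, is whether the mirror-image form of the oxolan-3-yl group would read the same as compound 4.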